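The source may hold more compounds than are shown below. What is called first, only, known or untested is meant among the compounds shown, and "the series" means these compounds.

Measured so far:
- compound 1 `COc1cc(/C=C/C(=O)c2cccc(-n3cc(-c4ccc(Cl)cc4)[nH]c3=O)c2)ccc1O` — 1800 nM
- compound 2 `COc1cc(/C=C/C(=O)c2cccc(-n3cc(-c4ccccc4)[nH]c3=O)c2)cc(OC)c1OC` — 1130 nM

In a functional assay on HCT-15 cells (Homo sapiens) for inhibition (on this read-out higher numbers stand for weaker inhibition of growth and lower numbers for stronger inhibition of growth), compound 1 has the highest of the two numbers, yet its nearest neighbour, compound 2, sits within the scatter of it, so the two cannot be told apart. Compound 3 `COc1cc(/C=C/C(=O)c2cccc(-n3cc(-c4ccccc4)[nH]c3=O)c2)ccc1O` differs from compound 1 in one place: hydrogen in place of chloro on an aromatic carbon. Among the compounds with values here, no measured pair shows this change, so its size is unknown. The expected step from compound 1 to compound 3 in this assay is a 1.2-fold higher number from compound 1 to compound 3 (0.09 log units; within the scatter), likely small. Compound 3 is estimated at 2200 nM, with a range from 800 nM to 6000 nM.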

Compound 3, concentration for 50% growth inhibition: 2730 nM
Estimate against measurement, compound 3: 1.2-fold (0.09 log units) below, within the range that was stated.
By their numbers in this assay, from the lowest: compounds 2, 1 and 3 (each within the scatter of the next, the first and the last beyond it).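

Within the data shown here, the swap from 4-chlorophenyl to phenyl gives a 1.5-fold higher number from compound 1 to compound 3 (0.18 log units; within the scatter) in this assay, the first direct reading of this change. Compound 1 and compound 3 cannot be told apart, so in this one pair the chloro on the aromatic carbon makes no measurable difference to growth inhibition. Nothing available explains this result.

On these data alone, what a methoxy group, an amine or a carboxylic acid would do at this position stays open. So does whether chloro and hydrogen would also match on a different core.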